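Chloro to bromo on the anilide: outlook for compound 3

A few compounds are considered here, and "the series" means these few. Any claim that something is new, unique, unknown or untested is made for them only; others in the source may bear on it.

Compound 1 `O=C(CSC(=S)N[C@H]1CCOC1=O)Nc1ccccc1F` carries a 2-fluorophenyl on the amide-type nitrogen. In a functional assay on EC9706 cells (Homo sapiens) for cytotoxicity, read by MTT assay, with a stated time of 72 h (on this read-out higher numbers stand for weaker inhibition and lower numbers for stronger inhibition), compound 1 gives only a limit of the assay, > 128000 nM. Compound 2 `O=C(CSC(=S)N[C@H]1CCOC1=O)Nc1ccc(Cl)cc1` carries 4-chlorophenyl in its place. In this assay compound 2 likewise gives only a limit, > 128000 nM. The step that the two limits leave unreadable from compound 1 to compound 2 cannot be read because both values sit at the limit of > 128000 nM in this assay, at which 2 of the 2 values shown sit. Compound 2 therefore stands at the limit of this assay, with no number of its own.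

Compound 3 `O=C(CSC(=S)N[C@H]1CCOC1=O)Nc1ccc(Br)cc1` differs from compound 2 by bromo in place of chloro on an aromatic carbon. Among the measured compounds shown here, the only measured step, a step that the two limits leave unreadable from compound 1 to compound 2, is unreadable, so no measured step gives a size for a halogen swap on this ring. Nothing here sets compound 3 apart from compound 2 in this assay, and the step that the limit leaves unreadable from compound 2 to compound 3 is expected to be none beyond the scatter, most likely again ending at a limit. Compound 3 is therefore estimated at 160000 nM, with a range of 60000 nM to 500000 nM, in this assay.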

Compound 3, half-maximal inhibitory concentration: 67400 nM
For compound 3 the middle estimate is 2.4-fold (0.38 log units) above the measured one; measured number inside the range.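

Among the compounds shown here, with 4-bromophenyl on the amide-type nitrogen, the series gains its only value in this assay that is a number rather than a limit, so a readable result can be obtained at this place on the shared core. Bromo in place of chloro gives an at least 1.8-fold lower number from compound 2 to compound 3 (0.27 log units; that floor lies within the scatter), and the change from 2-fluorophenyl gives an at least 1.8-fold lower number from compound 1 to compound 3 (0.27 log units; that floor lies within the scatter); both are floors, so neither step is secured beyond the scatter. The step from compound 1 to compound 2 cannot be read, and both floors rest on the same limit: the limit of > 128000 nM in this assay, at which 2 of the 3 values shown sit.

As far as these compounds go, the true size of either step stays open, as does whether a readable value is specific to bromo. An iodo, a methoxy or an amine at this place on the ring would test that, and a longer chain between the core and the carbonyl would test the rest of the scaffold.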